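The source may report more compounds than this note shows. Statements on the series, on what has been measured and on what is new or still open speak of the compounds shown alone.

Notes on the aryltriazene series in an ADME assay on MT4 cells (Homo sapiens) for cytotoxicity, read by MTT assay, with a stated time of 96 h; on this read-out higher numbers stand for lower toxicity in this test and lower numbers for higher toxicity in this test. Compound 1, `O=[N+]([O-])c1ccc(/N=N/N2CCCC2)cc1`, gives >= 100000 nM in this assay; that figure is a limit of the assay and not a number. Compound 2, `FC(F)(F)c1cccc(N(C[C@@H]2CCCN3CCCC[C@H]23)/N=N/c2ccccc2)c1`, gives 17000 nM in this assay and stands as the only plain number shown, the other value shown being (the limit of >= 100000 nM in this assay, at which 1 of the 2 values shown sits). Within the data shown here, no measured pair differing in a single place is available, so no step size is known.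

Compound 3, `CN(C)CCCN(/N=N/c1ccccc1)c1cccc(C(F)(F)F)c1`, is not yet measured. It differs from compound 2 by a group of 5 heavy atoms (4 carbon, 1 nitrogen; no ring) in place of a group of 10 heavy atoms (9 carbon, 1 nitrogen; 2 six-membered non-aromatic rings with 1 hetero atom each), on a saturated chain carbon bound to a nitrogen on an aromatic ring: a 2-(dimethylamino)ethyl group enters in place of the two six-membered non-aromatic rings, on a saturated chain carbon bound to a nitrogen on an aromatic ring. Nothing among the shown values ties such a change to a shift in this assay. The step is expected to be a 1.8-fold higher number from compound 2 to compound 3 (0.25 log units; within the scatter), no more than the usual scatter or a little toward lower toxicity. Compound 3 is therefore estimated at 30000 nM, with a range from 10000 nM to 100000 nM.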

Compound 3, half-maximal cytotoxic concentration: 14000 nM
Estimate against measurement, compound 3: 2.1-fold (0.33 log units) above; the measured number falls inside the stated range.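

In this assay, a 2-(dimethylamino)ethyl group in place of the two six-membered non-aromatic rings, on a saturated chain carbon bound to a nitrogen on an aromatic ring, gives a 1.2-fold lower number from compound 2 to compound 3 (0.08 log units; within the scatter). Among these compounds, this is the first single-place comparison, and it shows that at this place both rings and the two defined stereocentres can be exchanged for an open chain without a difference beyond the usual scatter. No measured property among the data shown bears on this result.

Still open, from the compounds shown here alone, is whether a primary amine, a carboxylic acid or a longer chain at this place would stay within the scatter of compound 2 and compound 3, and whether the trifluoromethyl group on the aromatic ring has any bearing on these values. Among the compounds shown here, compound 1 gives >= 100000 nM, which is a limit of the assay and not a number, and it differs from the other compounds in more than one place, so it offers no step to read.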